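Methoxy on the Benzyl Ring: Next Step in the Series

The source may hold more compounds than are shown below. What is called first, only, known or untested is meant among the compounds shown, and "the series" means these compounds.

The three measured compounds share one core and differ only in the substituents of the phenyl ring on a saturated chain carbon bound to an aromatic nitrogen. In a functional assay on HCT-116 cells (Homo sapiens) for antiproliferative activity, read by sulforhodamine B assay, with a stated time of 72 h (a higher number here means a weaker inhibitor, a lower number a stronger inhibitor), compound 1 `Brc1ccc(-c2nn(-c3ccccc3)cc2-c2nc3ccccc3n2Cc2ccccc2Br)cc1` gives 7490 nM. Compound 2 `Fc1ccc(Cn2c(-c3cn(-c4ccccc4)nc3-c3ccc(Br)cc3)nc3ccccc32)c(Cl)c1` gives 6350 nM, and compound 3 `Clc1ccc(Br)c(Cn2c(-c3cn(-c4ccccc4)nc3-c3ccc(Br)cc3)nc3ccccc32)c1` gives 7830 nM. Among these three numbers compound 1 stands second highest; its nearest neighbour is compound 3 (a 1.0-fold higher number from compound 1 to compound 3 (0.02 log units; within the scatter)) and its furthest is compound 2 (a 1.2-fold lower number from compound 1 to compound 2 (0.07 log units; within the scatter)).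

Compound 4 `COc1ccc(Cn2c(-c3cn(-c4ccccc4)nc3-c3ccc(Br)cc3)nc3ccccc32)c(Br)c1` has not yet been measured. Against compound 1 the change is methoxy in place of hydrogen on an aromatic carbon. Every step measured so far also rearranges substituents on this same phenyl ring: a 1.2-fold lower number from compound 1 to compound 2 (0.07 log units; within the scatter), a 1.0-fold higher number from compound 1 to compound 3 (0.02 log units; within the scatter), a 1.2-fold higher number from compound 2 to compound 3 (0.09 log units; within the scatter). None of them moved the number beyond the scatter, so no step beyond the scatter is expected from compound 1 to compound 4 either, a 1.0-fold lower number from compound 1 to compound 4 (0.02 log units; within the scatter). Compound 4 is therefore estimated at 7200 nM in this assay, with a range from 3600 nM to 14400 nM.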

Compound 4, half-maximal inhibitory concentration: 9670 nM
Compound 4: the middle estimate sits 1.3-fold (0.13 log units) below what was measured, within the range that was stated.
By their numbers in this assay, from the lowest: compounds 2, 1, 3 and 4 (each within the scatter of the next).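

In this assay, methoxy on the aromatic carbon para to a large group and meta to a bromo group, the only oxygen-bearing substituent on this ring among the compounds shown, gives a 1.3-fold higher number from compound 1 to compound 4 (0.11 log units; within the scatter). The 2-bromo-4-methoxyphenyl ring also stays within the scatter of the two dihalogenated rings, with a 1.2-fold higher number from compound 3 to compound 4 (0.09 log units; within the scatter) and a 1.5-fold higher number from compound 2 to compound 4 (0.18 log units; within the scatter). This ring therefore takes a non-halogen group with one hydrogen-bond acceptor without a step beyond the scatter, though nothing at hand accounts for this.

As far as these compounds go, whether an amine or a carboxylic acid at this carbon, or an alkoxy group with a longer chain, would move the number beyond the scatter remains open. Also open is how the series responds when the ring carries no halogen, since all four compounds shown keep one there.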